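The source may hold more compounds than are shown below. What is called first, only, known or untested is meant among the compounds shown, and "the series" means these compounds.

In an ADME assay on a cell-free system (plasma, Rattus norvegicus) for protein binding, compound 3 `O=C(Nc1ccc(Cl)c(C(F)(F)F)c1)N[C@H]1CCN(c2ccnc(NC3CC3)n2)C1` gives 99.9% and stands level with compound 2 `CCNc1nccc(N2CC[C@H](NC(=O)Nc3ccc(Cl)c(C(F)(F)F)c3)C2)n1` at 99.9% with the lowest unbound fraction of the three, while compound 1 `CNc1nccc(N2CC[C@H](NC(=O)Nc3cc(OC)cc(OC)c3)C2)n1` at 96.7% lies beyond the scatter from both. Going by the values given here, the change to compound 4 `Nc1nccc(N2CC[C@H](NC(=O)Nc3ccc(Cl)c(C(F)(F)F)c3)C2)n1` is hydrogen in place of cyclopropyl on a nitrogen on an aromatic ring, counted as hydrogen in place of cyclopropyl on a nitrogen on an aromatic ring and not yet tested, since no measured step leaves that nitrogen without a substituent. The nearest evidence is no change at the digits printed from compound 2 to compound 3 (within the scatter) for cyclopropyl in place of ethyl, which sets no size for removal. Compound 1 differs elsewhere too and sets none either. A small step towards more free compound is expected, given as a 4.0-fold higher unbound fraction from compound 3 to compound 4 (0.60 log units; beyond the scatter) in this estimate. The expected value for compound 4 is 99.6% in this assay with 98.5% to 99.9% as its range.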

Compound 4, plasma protein binding: 99.4%
For compound 4 the middle estimate is 1.5-fold (0.18 log units) (unbound fraction) below the measured one; low and high end bracket the measured number.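

On a nitrogen on an aromatic ring, removing the substituent is the only change shown that moves this assay: hydrogen in place of cyclopropyl gives a 6.0-fold higher unbound fraction from compound 3 to compound 4 (0.78 log units; beyond the scatter) and hydrogen in place of ethyl gives a 6.0-fold higher unbound fraction from compound 2 to compound 4 (0.78 log units; beyond the scatter) in the same direction. Cyclopropyl and ethyl stand level here, so the free amino compound separates from both substituted compounds by one step size. Nothing shown accounts for this shift.

Open, as far as these compounds go, is whether a propyl chain or an acetyl group on that nitrogen stays level with ethyl and cyclopropyl or moves towards the free amino compound. Also open, from the compounds shown here alone, is whether removing the substituent gives a similar step with the dimethoxyphenyl urea of compound 1.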